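Working notes: second aryl swap in the bisarylidene series

The source may report more compounds than this note shows. Statements on the series, on what has been measured and on what is new or still open speak of the compounds shown alone.

Measured so far:
compound 1 `C=CCn1c(=O)/c(=C\c2cc(Br)ccc2F)[nH]c(=O)/c1=C\c1ccccc1OC` — in a functional assay on A549 cells (Homo sapiens) for cytotoxicity, read by CCK-8 assay, with a stated time of 72 h (a higher number here means a weaker inhibitor, a lower number a stronger inhibitor), compound 1 gives "not active" (no number reported).
compound 2 `C=CCn1c(=O)/c(=C\c2cccc(Br)c2)[nH]c(=O)/c1=C\c1ccccc1OC` — in this assay compound 2 gives 5400 nM.
compound 3 `C=CCn1c(=O)/c(=C\c2ccccc2C(F)(F)F)[nH]c(=O)/c1=C\c1ccccc1OC` — in this assay compound 3 gives 7000 nM.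

Compound 2 holds the lowest of the two numbers; nearest is compound 3, with a 1.3-fold higher number from compound 2 to compound 3 (0.11 log units; within the scatter). Compound 4 `C=CCn1c(=O)/c(=C\c2cccc(Br)c2)[nH]c(=O)/c1=C\c1cccc(Br)c1` differs from compound 2 by 3-bromophenyl in place of 2-methoxyphenyl on a double-bonded chain carbon bound to an aromatic carbon. Among the compounds with values here, no measured step touches this aryl: the single recorded step, a 1.3-fold higher number from compound 2 to compound 3 (0.11 log units; within the scatter), changes the other aryl and stays within the scatter, and compound 1 merely shows that the other aryl can be changed so that no number is obtained. With nothing bearing on this change, no step beyond the scatter is expected in this assay in either direction. Compound 4 is therefore estimated at 5400 nM, range 1800 nM to 16000 nM, an expected no change at the digits printed from compound 2 to compound 4 (within the scatter).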

Compound 4, half-maximal inhibitory concentration: "not active" (no number reported)
The entry for compound 4 holds no number; there is nothing to compare the estimate with.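

Compound 4 gives "not active" (no number reported) in this assay and so yields no readable step from compound 2; no evidence bears on this result. On these data alone, how far 3-bromophenyl in place of 2-methoxyphenyl shifts the number remains open.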